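Moving a trifluoromethyl group and watching cell toxicity

The source may report more compounds than this note shows. Statements on the series, on what has been measured and on what is new or still open speak of the compounds shown alone.

Three compounds share one core and differ only in the group on the benzene ring attached to the chain carbon. Compound 1 `N#Cc1cccc(Cn2ccc3nc(-c4ccccc4)nc-3c2)c1` carries a cyano group. In an ADME assay on MDBK cells (Bos taurus) for cytotoxicity (on this read-out higher numbers stand for lower toxicity in this test and lower numbers for higher toxicity in this test), compound 1 gives > 100000 nM, which is a limit of the test, not a number. Compound 2 `N#Cc1ccc(Cn2ccc3nc(-c4ccccc4)nc-3c2)cc1` gives > 100000 nM in this assay, again a limit. Compound 3 `FC(F)(F)c1cccc(Cn2ccc3nc(-c4ccccc4)nc-3c2)c1` gives 98000 nM in this assay. The two cores differ as follows: 4-cyanophenyl in place of 3-cyanophenyl on a saturated chain carbon bound to an aromatic nitrogen. That step is a step that the two limits leave unreadable from compound 1 to compound 2. The change trifluoromethyl in place of cyano on an aromatic carbon gives an at least 1.0-fold lower number from compound 1 to compound 3 (0.00 log units; that floor lies within the scatter), where the floor comes from the limit of > 100000 nM in this assay, at which 2 of the 3 values shown sit. Compound 4 `FC(F)(F)c1ccc(Cn2ccc3nc(-c4ccccc4)nc-3c2)cc1` is not yet measured; it carries the same kind of change from compound 2, (trifluoromethyl in place of cyano on an aromatic carbon), though here the group sits para to a large group rather than meta to a large group. Since the measured step of an at least 1.0-fold lower number from compound 1 to compound 3 (0.00 log units; that floor lies within the scatter) stays within the scatter, the corresponding step is expected to be a number no higher from compound 2 to compound 4 (the limit leaves the size open). Compound 4 is therefore estimated at 100000 nM, between 50000 nM and 200000 nM.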

Compound 4, half-maximal cytotoxic concentration: 84000 nM
Compound 4: middle estimate off by 1.2-fold (0.08 log units), on the high side; measured number inside the range.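

In this assay, trifluoromethyl in place of cyano on the core of compound 2 gives an at least 1.1-fold lower number from compound 2 to compound 4 (0.07 log units; that floor lies within the scatter). So what was seen on the first core is not contradicted on the second, since neither step shows a change that stands clear of the usual scatter: the same change on two cores in this assay, an at least 1.0-fold lower number (0.00 log units; that floor lies within the scatter) from compound 1 to compound 3 and an at least 1.1-fold lower number (0.07 log units; that floor lies within the scatter) from compound 2 to compound 4; the limit leaves it open whether they differ. This does not show that the change has the same size on both cores, or any real effect at all, as each step starts from a limit of the test and not from a number, so only a floor can be read from it: the limit of > 100000 nM in this assay, at which 2 of the 4 values shown sit.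

The compounds shown leave open how this test would respond to an amine or a carboxylic acid on the benzene ring, in place of cyano or trifluoromethyl. They also leave open whether a longer chain in place of the single saturated chain carbon would bring the numbers clearly inside the range of the test, where steps could be read in full.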